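Dropping the chloro from compound 1

This account rests on a few compounds, and the source may have more. Where it says the series, first, only, none or still open, it means among the compounds named here.

Compound 1 `O=C1OC(c2ccc(Cl)c([N+](=O)[O-])c2)=N/C1=C\c1ccncc1`: 0%
Compound 2 `Cc1cc(C2=N/C(=C\c3cccnc3)C(=O)O2)ccc1Br`: 88%
Compound 3 `COc1cc(C2=N/C(=C\c3cccnc3)C(=O)O2)cc(OC)c1OC`: 26%

Of the compounds shown here, three sharing one core have been measured in an assay on isolated protein for inhibition of Death-associated protein kinase 3 (Homo sapiens), tested at 1 uM; a lower number here means a weaker effect, a higher number a stronger effect of the compound at the concentration tested. Compound 1 gives 0%, the lowest of the three numbers. Its nearest neighbour is compound 3, which gives 26%, a gap beyond the scatter. Furthest from it is compound 2, which gives 88%, again a gap beyond the scatter.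

Compound 4 `O=C1OC(c2cccc([N+](=O)[O-])c2)=N/C1=C\c1ccncc1` has not been measured. It differs from compound 1 in one place: hydrogen in place of chloro on an aromatic carbon. Among the measured compounds shown here, no step between two measured compounds isolates this kind of change, so there is nothing measured to lean on for its size. For the measured compounds named here, what is known is only that compound 1 starts from the floor of the read-out, so a drop from there cannot show, and that a rise would have to come from losing a single chlorine on an aromatic carbon ortho to a nitro group.

Compound 4 is therefore expected to stay near compound 1, with a step of a number 8 percentage points higher from compound 1 to compound 4 (within the scatter) that is small and, if anything, slightly upward. The estimate for compound 4 in this assay is 8%, with a range from 0% to 30%.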

Compound 4, a percentage reported as inhibition, at one concentration (the size of the read-out at that concentration, not a potency): 0%
Compound 4: the middle estimate sits 8 percentage points above what was measured; measured number inside the range.
By their numbers in this assay, from the lowest: compounds 1 and 4 (each within the scatter of the next); then compound 3; then compound 2.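

In this assay, among the compounds shown here, the exchange of chloro for hydrogen on the aromatic carbon ortho to a nitro group gives no change at the digits printed from compound 1 to compound 4 (within the scatter) and provides the first step here that isolates a single change. Removing the chlorine does not lift the read-out, so the chlorine alone does not separate compound 1 from a measurable effect: compound 4 gives 0% as well. Both compounds sit at the floor of the read-out, so this step shows only that hydrogen brings no gain at this position, not that chloro and hydrogen are equivalent there, and nothing at hand explains the flat result.

The compounds shown leave open whether any group at this position can raise the number off the floor, for example an amine or a carboxylic acid in place of the chloro. They also leave open what the nitro group contributes, as no pair shown changes it alone, and an amine in its place on the same ring would test this directly.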